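The source may hold more compounds than are shown below. What is called first, only, known or untested is meant among the compounds shown, and "the series" means these compounds.

Measured so far in a functional assay (aorta) with Oryctolagus cuniculus as the target; on this read-out lower numbers stand for stronger inhibition and higher numbers for weaker inhibition:
- compound 1, `CCc1c[nH]c(-c2nn(Cc3ccccc3F)c3ncccc23)n1`: 600 nM
- compound 2, `OCc1ccnc(-c2nn(Cc3ccccc3F)c3ncccc23)n1`: 1300 nM
- compound 3, `Nc1ccnc(-c2nn(Cc3ccccc3F)c3ncccc23)n1`: 270 nM; 265000 nM (2 entries)

Compound 2 gives the highest of the two single numbers in this assay. Among the measured compounds shown here, its nearest neighbour is compound 1, and the one change between them, a 2.2-fold higher number from compound 1 to compound 2 (0.34 log units; beyond the scatter), is the only step in this set that rests on two single numbers. Compound 3 has been measured more than once with very different outcomes, (the several entries of compound 3 in this assay, 270 nM; 265000 nM (2 entries)), so it gives no single number to compare against.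

Compound 4, `Fc1ccccc1Cn1nc(-c2cc[nH]n2)c2cccnc21`, has not yet been measured. It differs from compound 2 in one place: 1H-pyrazol-3-yl in place of 4-(hydroxymethyl)pyrimidin-2-yl on an aromatic carbon. The 1H-pyrazol-3-yl that enters is a five-membered aromatic ring with two hetero atoms, like the 4-ethyl-1H-imidazol-2-yl of compound 1, so the change partly reverses the step from compound 1 to compound 2. On that basis a modest move downward, roughly back toward compound 1, is expected, though the two rings are not the same and the step could also stay within the scatter. Compound 4 is therefore estimated at 500 nM, with a range from 150 nM to 2500 nM, which would mean an expected step of a 2.6-fold lower number from compound 2 to compound 4 (0.41 log units; beyond the scatter).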

Compound 4, half-maximal inhibitory concentration: 1800 nM
Estimate against measurement, compound 4: 3.6-fold (0.56 log units) below, within the range that was stated.
By their numbers in this assay, from the lowest: compound 1; then compounds 2 and 4 (each within the scatter of the next).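

Read in this assay, the exchange of rings at this aromatic carbon gives a 1.4-fold higher number from compound 2 to compound 4 (0.14 log units; within the scatter) and so cannot be told apart from no change. A five-membered aromatic ring with two hetero atoms is thus not enough at this position to match compound 1, for 1H-pyrazol-3-yl in place of 4-ethyl-1H-imidazol-2-yl gives a 3.0-fold higher number from compound 1 to compound 4 (0.48 log units; beyond the scatter) and leaves that gap standing. Ring size therefore does not follow the numbers across these compounds, and no measurement shown explains what sets compound 1 apart.

From the compounds shown here alone, whether an ethyl group, a longer chain or a carboxylic acid on the 1H-pyrazol-3-yl ring would move the number remains open. Steps involving compound 3 cannot be read, its entries lying far apart: the several entries of compound 3 in this assay, 270 nM; 265000 nM (2 entries).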